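Replacing the Benzyl Group on the Amine of Compound 1

The source may report more compounds than this note shows. Statements on the series, on what has been measured and on what is new or still open speak of the compounds shown alone.

Compound 1, `COc1cc(Oc2cccc(Nc3ccccc3)c2)cc(OC)c1CNCc1ccccc1`: 3340 nM in a functional assay on HT-29 cells (Homo sapiens) for inhibition, read by MTT assay, with a stated time of 72 h; on this read-out higher numbers stand for weaker inhibition and lower numbers for stronger inhibition
Compound 2, `COc1cc(Oc2cccc(Nc3ccccc3)c2)cc(OC)c1CNCc1ccc(F)cc1`: 2750 nM in this assay

Among the compounds with values here, compound 1 holds the highest of the two numbers in this assay; its only neighbour is compound 2, and the step of a 1.2-fold lower number from compound 1 to compound 2 (0.08 log units; within the scatter) reads as a fluoro in place of hydrogen on an aromatic carbon. Compound 3, `COc1cc(Oc2cccc(Nc3ccccc3)c2)cc(OC)c1CNC(C)C`, is not yet measured. It differs from compound 1 in one place: isopropyl in place of benzyl on an amine nitrogen. Within the data shown here, no measured step touches this amine nitrogen, and the one step that exists, from compound 1 to compound 2, lies elsewhere on the shared core and stays within the scatter, so the two values give no direct guide for this change. Compound 3 is therefore expected to sit near compound 1, with a step of a 1.3-fold higher number from compound 1 to compound 3 (0.13 log units; within the scatter) that may well fall inside the scatter. The estimate for compound 3 in this assay is 4500 nM, with a range from 1500 nM to 14000 nM.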

Compound 3, half-maximal inhibitory concentration: > 20000 nM
Compound 3 was reported as a limit; the forecaster's own chance of this, stated with the estimate: 5%; middle value at least 4.4-fold (0.64 log units) from the limit.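

Compound 3 is reported in this assay only as a limit, not as a number: the limit of > 20000 nM in this assay, at which 1 of the 3 values shown sits. Even so, the amine nitrogen proves sensitive where the fluoro change was not: isopropyl in place of benzyl gives an at least 5.9-fold higher number from compound 1 to compound 3 (0.77 log units; beyond the scatter), and isopropyl in place of 4-fluorobenzyl gives an at least 7.2-fold higher number from compound 2 to compound 3 (0.86 log units; beyond the scatter), both beyond the scatter, whereas a 1.2-fold lower number from compound 1 to compound 2 (0.08 log units; within the scatter) stayed within it. Among these compounds, then, the benzyl and 4-fluorobenzyl groups go with measurable numbers, while the isopropyl group, which carries no ring, goes with the limit.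

The compounds shown do not separate the loss of the aromatic ring from the loss of heavy atoms. As far as these compounds go, whether a cyclohexylmethyl group or a longer chain on this nitrogen would keep the number close to that of compound 1 remains open.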